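Working notes: moving substituents on the phenyl group

A few compounds are considered here, and "the series" means these few. Any claim that something is new, unique, unknown or untested is made for them only; others in the source may bear on it.

Measured so far in a functional assay on HepG2 cells (Homo sapiens) for antiproliferative activity, read by spectrophotometry, with a stated time of 2 days; a higher number here means a weaker inhibitor of growth, a lower number a stronger inhibitor of growth:
- compound 1 `Cc1cc(F)ccc1Nc1ncc(C(F)(F)F)c(N2Cc3cccc(N(C)S(C)(=O)=O)c3C2)n1` gives 16800 nM
- compound 2 `CN(c1cccc2c1CN(c1nc(Nc3ccc(Cl)c(C(F)(F)F)c3)ncc1C(F)(F)F)C2)S(C)(=O)=O` gives 16000 nM

In this assay compound 2 stands at 16000 nM and is level with compound 1 within the scatter. Compound 3 `CN(c1cccc2c1CN(c1nc(Nc3cc(Cl)cc(C(F)(F)F)c3)ncc1C(F)(F)F)C2)S(C)(=O)=O` has 3-chloro-5-(trifluoromethyl)phenyl in place of 4-chloro-3-(trifluoromethyl)phenyl on a nitrogen on an aromatic ring and keeps the shared core.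

Among the measured compounds shown here, only one measured step bears on this change: a 1.1-fold lower number from compound 1 to compound 2 (0.02 log units; within the scatter). It replaced the group at the same place and did not move the number beyond the scatter. For the measured compounds named here, no measured pair tests this rearrangement of chlorine and trifluoromethyl directly, so the evidence is thin.

The expected result is a 1.1-fold lower number from compound 2 to compound 3 (0.03 log units; within the scatter), with no firm direction and no shift beyond the scatter. For compound 3 the estimated value is 15000 nM, with an expected range of 7000 nM to 32000 nM in this series.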

Compound 3, concentration for 50% growth inhibition: 9900 nM
The estimate for compound 3 lay 1.5-fold (0.18 log units) above the measured number; the measured number falls inside the stated range.
By their numbers in this assay, from the lowest: compounds 3, 2 and 1 (each within the scatter of the next).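

In this assay, rearranging the same chlorine and trifluoromethyl substituents on the phenyl group, from 4-chloro-3-(trifluoromethyl)phenyl to 3-chloro-5-(trifluoromethyl)phenyl, gives a 1.6-fold lower number from compound 2 to compound 3 (0.21 log units; within the scatter), so this rearrangement on the nitrogen does not shift the number beyond the scatter. Replacing 4-fluoro-2-methylphenyl with 3-chloro-5-(trifluoromethyl)phenyl gives a 1.7-fold lower number from compound 1 to compound 3 (0.23 log units; within the scatter), so all three phenyl groups at this place now read as level within the scatter. Nothing on hand offers an explanation for this result.

Going by these compounds, it remains open whether any group on this nitrogen can move the number beyond the scatter, for example a phenyl group carrying an amine or a carboxylic acid. On these data alone, it is also open whether this level reading would hold with a different shared core.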